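The compounds below may be only part of what the source reports. "The series", "measured", "known", "first", "only" and "open" are said of these compounds alone.

Within the data shown here, in an ADME assay on Vero cells (Chlorocebus sabaeus) for cytotoxicity, read by MTT assay, with a stated time of 72 h (on this read-out higher numbers stand for lower toxicity in this test and lower numbers for higher toxicity in this test), compound 1 (`COc1c(N2CCN(CCC(C)=O)C(C)C2)c(F)cc2c(=O)c(C(=O)O)cn(C3CC3)c12`) gives 9.84 ug/mL, while compound 2 (`COc1c(N2CCN(C/C(C)=N/NC(N)=O)C(C)C2)c(F)cc2c(=O)c(C(=O)O)cn(C3CC3)c12`) gives 500 ug/mL, the higher of the two numbers so far. Compound 3 (`COc1c(N2CCN(C/C(C)=N/NC(=O)c3ccncc3)C(C)C2)c(F)cc2c(=O)c(C(=O)O)cn(C3CC3)c12`) differs from compound 2 in one place: pyridin-4-yl in place of amino on a carbonyl carbon. Put simply, pyridin-4-yl stands in place of amino on a carbonyl carbon. Among the measured compounds shown here, only one measured step bears on this change: a 51-fold higher number from compound 1 to compound 2 (1.71 log units; beyond the scatter). That large step introduced the group altered here, so it suggests that changes to this group can shift the number widely. For the measured compounds named here, it contains no example of pyridin-4-yl, however, so it offers only weak guidance. With compound 2 at 500 ug/mL, the highest number seen, a move downward is expected, but a smaller one than the earlier step. The estimated step is expected to be a 2.8-fold lower number from compound 2 to compound 3 (0.44 log units; beyond the scatter). For compound 3, the estimated value is 180 ug/mL, with an expected range of 40 ug/mL to 600 ug/mL.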

Compound 3, half-maximal cytotoxic concentration: 250 ug/mL
Estimate against measurement, compound 3: 1.4-fold (0.14 log units) below; measured number inside the range.
By their numbers in this assay, from the lowest: compound 1; then compounds 3 and 2 (each within the scatter of the next).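

In this assay, pyridin-4-yl in place of amino on the carbonyl carbon gives a 2.0-fold lower number from compound 2 to compound 3 (0.30 log units; within the scatter), which lies within the usual scatter, so this position takes a six-membered aromatic ring with no change that can be told from repeat-to-repeat variation. The large gap to the short side chain also survives with this new end group, at a 25-fold higher number from compound 1 to compound 3 (1.40 log units; beyond the scatter), so it does not depend on the amino group alone. Nothing measured here gives a reason for these numbers.

Only two end groups on this carbonyl carbon are shown, so it remains open whether a phenyl ring or a simple methyl group would give a similar number. Going by these compounds, it also remains open how an amine or a carboxylic acid attached to the pyridin-4-yl ring would read in this assay.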